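This account rests on a few compounds, and the source may have more. Where it says the series, first, only, none or still open, it means among the compounds named here.

In a functional assay on CHO-K1 cells with Glucose-dependent insulinotropic receptor (Homo sapiens) as the target, read by a luciferase reporter, with a stated time of 5 h (a higher number here means a larger maximal response, a lower number a smaller maximal response), compound 1 `CC(C)OC(=O)N1CCC(Oc2ncnc3c2CCN3c2ccc(S(C)(=O)=O)nc2)CC1` gives 97%.
In this assay compound 2 `CC(C)OC(=O)N1CCC(Oc2ncnc3c2CCN3c2ccc(C#N)cn2)CC1` gives 105%.

Compound 2 holds the higher of these two numbers, but the gap a number 8 percentage points higher from compound 1 to compound 2 (within the scatter) lies within the scatter, so the two compounds cannot be ordered. Compound 3 `CC(C)OC(=O)N1CCC(Oc2ncnc3c2CCN3c2ccc(S(C)(=O)=O)c(F)c2)CC1` differs from compound 2 at this nitrogen: 3-fluoro-4-(methylsulfonyl)phenyl in place of 5-cyanopyridin-2-yl on a nitrogen on an aromatic ring in a ring. For the measured compounds named here, the only measured step, a number 8 percentage points higher from compound 1 to compound 2 (within the scatter), exchanged the group on this same nitrogen and produced no change beyond the scatter; it is the one step that bears here, and it points to no shift beyond the scatter. Compound 3 is therefore expected to give 98%, between 85% and 110%, which means an expected step of a number 7 percentage points lower from compound 2 to compound 3 (within the scatter).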

Compound 3, largest response reached (reported as percent of maximum), in percent of the reference or control that the assay uses: 109%
Beside the measured number, compound 3's estimate is 11 percentage points below it, within the range that was stated.
By their numbers in this assay, from the lowest: compounds 1, 2 and 3 (each within the scatter of the next, the first and the last beyond it).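

In this assay, the exchange of 5-cyanopyridin-2-yl for 3-fluoro-4-(methylsulfonyl)phenyl on this nitrogen gives a number 4 percentage points higher from compound 2 to compound 3 (within the scatter), so a ring of carbon only is tolerated here. For the compounds shown here, the step of a number 12 percentage points higher from compound 1 to compound 3 (beyond the scatter) is the first at this position to pass the scatter, showing that this group can shift the maximal response, if only slightly. Nothing available explains this shift. Still open, from the compounds shown here alone, is how the maximal response changes with a phenyl ring carrying a carboxylic acid or an amine on this nitrogen, or with a simple alkyl chain in place of the ring.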